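Acetamido in place of (methylsulfonyl)carbamoyl on the shared core

The compounds below may be only part of what the source reports. "The series", "measured", "known", "first", "only" and "open" are said of these compounds alone.

Of the compounds shown here, three built on one core have been measured in a functional assay on CAL1 cells for inhibition of chemerin-like receptor 1 (Homo sapiens), with a stated time of 45 min; a lower number here means a stronger inhibitor, a higher number a weaker inhibitor. Compound 1 `CCCCN(c1nc2c(NS(C)(=O)=O)cccc2o1)[C@H](C)c1ccc(-c2ccccc2-c2nnn[nH]2)cc1` carries a methanesulfonamido group and gives 14 nM. Compound 2 `CCCCN(c1nc2c(C(=O)NC)cccc2o1)[C@H](C)c1ccc(-c2ccccc2-c2nnn[nH]2)cc1` carries methylcarbamoyl at that aromatic carbon and gives 110 nM, the step being a 7.9-fold higher number from compound 1 to compound 2 (0.90 log units; beyond the scatter). Compound 3 `CCCCN(c1nc2c(C(=O)NS(C)(=O)=O)cccc2o1)[C@H](C)c1ccc(-c2ccccc2-c2nnn[nH]2)cc1` carries (methylsulfonyl)carbamoyl and gives 14 nM. On these numbers compound 3 stands level with compound 1 at the digits shown, the two together the lowest of the three, and it is set apart from compound 2 by a 7.9-fold lower number from compound 2 to compound 3 (0.90 log units; beyond the scatter), while no change at the digits printed from compound 1 to compound 3 (within the scatter).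

Compound 4 `CCCCN(c1nc2c(NC(C)=O)cccc2o1)[C@H](C)c1ccc(-c2ccccc2-c2nnn[nH]2)cc1` awaits measurement in this assay. It differs from compound 3 in one place: acetamido in place of (methylsulfonyl)carbamoyl on an aromatic carbon. Going by the values given here, two measured steps bear on this change. One, no change at the digits printed from compound 1 to compound 3 (within the scatter), shows that the two sulfur-bearing groups are interchangeable here. The other, a 7.9-fold lower number from compound 2 to compound 3 (0.90 log units; beyond the scatter), shows that the presence of methylsulfonyl rather than a plain methyl on the amide-type nitrogen is worth a modest step. Acetamido keeps a single hydrogen-bond donor but has no sulfur at all, so a modest rise in the number, of roughly the size seen between compound 2 and compound 3, is expected. Compound 4 is therefore estimated to give 70 nM, with a range of 20 nM to 250 nM, a step of a 5.0-fold higher number from compound 3 to compound 4 (0.70 log units; beyond the scatter).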

Compound 4, half-maximal inhibitory concentration: 22 nM
The estimate for compound 4 lay 3.2-fold (0.50 log units) above the measured number; the range from low to high includes it.
By their numbers in this assay, from the lowest: compounds 1, 3 and 4 (each within the scatter of the next); then compound 2.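

In this assay, this aromatic carbon accepts acetamido as readily as either sulfur-bearing group: a 1.6-fold higher number from compound 3 to compound 4 (0.20 log units; within the scatter) and a 1.6-fold higher number from compound 1 to compound 4 (0.20 log units; within the scatter) both stay within the scatter, so neither sulfur nor the larger (methylsulfonyl)carbamoyl is needed to reach this level. The earlier compounds shown here left open whether a low number at this carbon depended on a methylsulfonyl group, but a 5.0-fold lower number from compound 2 to compound 4 (0.70 log units; beyond the scatter) shows that an amide without one can also differ clearly from methylcarbamoyl, so the gap to compound 2 is tied to more than the presence of methylsulfonyl, and compound 2 alone stands apart among the four, with compound 3 showing that a group joined through its carbonyl can still sit with those joined through nitrogen. Nothing measured here explains why acetamido and methylcarbamoyl differ while acetamido and the two sulfur-bearing groups do not.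

As far as these compounds go, whether a plain amine, a carboxylic acid or a longer acyl chain such as propionamido at this carbon would stay with compounds 1, 3 and 4 or fall with compound 2 remains open. Also open, from the compounds shown here alone, is whether these groups would keep the same order of values if the butyl chain on the shared core were replaced by a shorter chain.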